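Amino for hydroxy on two biaryl cores

A few compounds are considered here, and "the series" means these few. Any claim that something is new, unique, unknown or untested is made for them only; others in the source may bear on it.

Measured compounds:
compound 1 `COc1ccc(-c2cccc(O)c2)c(OC)c1` 54 ug/mL
compound 2 `COc1ccc(-c2cccc(N)c2)c(OC)c1` 49 ug/mL
compound 3 `COc1ccc(-c2ccc(O)cc2)cc1OC` 26 ug/mL

In a functional assay on HT-29 cells (Homo sapiens) for cytotoxicity, read by MTT assay, with a stated time of 3 days (on this read-out higher numbers stand for weaker inhibition and lower numbers for stronger inhibition), compound 1 gives 54 ug/mL and compound 2 gives 49 ug/mL. Between them stands one change, amino in place of hydroxy on an aromatic carbon
and this step, a 1.1-fold lower number from compound 1 to compound 2 (0.04 log units; within the scatter), lies within the scatter. Compound 3 carries a different core; the difference between the two cores is not broken down here. In this assay compound 3 gives 26 ug/mL, the lowest of the three numbers, though its gap to compound 2 is within the scatter and only its gap to compound 1 is beyond it.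

Compound 4 `COc1ccc(-c2ccc(N)cc2)cc1OC` has not been measured. It differs from compound 3 by amino in place of hydroxy on an aromatic carbon
which is the same kind of change as that from compound 1 to compound 2, but here the group sits para to a large group rather than meta to it. Because a 1.1-fold lower number from compound 1 to compound 2 (0.04 log units; within the scatter) was within the scatter, compound 4 is expected to sit close to compound 3, with a step of about a 1.1-fold lower number from compound 3 to compound 4 (0.03 log units; within the scatter). The estimate for compound 4 in this assay is 24 ug/mL, expected between 13 ug/mL and 45 ug/mL.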

Compound 4, half-maximal inhibitory concentration: 2 ug/mL
The estimate for compound 4 lay 12-fold (1.08 log units) above the measured number; the measured number lies below the stated range.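

In this assay, amino in place of hydroxy on an aromatic carbon, para to a large group, gives a 13-fold lower number from compound 3 to compound 4 (1.11 log units; beyond the scatter), a large step on this core. The change therefore does not carry over at a constant size between the two cores shown, and the effect seen on one core could not be read across to the other: the same change on two cores in this assay, a 1.1-fold lower number (0.04 log units; within the scatter) from compound 1 to compound 2 and a 13-fold lower number (1.11 log units; beyond the scatter) from compound 3 to compound 4, 12-fold (1.07 log units) apart, beyond the scatter of two such steps

This does not show what sets the gap, since the two pairs differ both in their core and in where the group sits, and two pairs give no rule for a third core.

From the compounds shown here alone, it remains open whether a dimethylamino group or an acetamide in place of the amino group would retain the number of compound 4, 2 ug/mL. Going by these compounds, it also remains open whether a methoxy group or a fluorine atom at that place would fall closer to compound 3 or to compound 4.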